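A Second Methoxy Added to Compound 2

The source may hold more compounds than are shown below. What is called first, only, known or untested is meant among the compounds shown, and "the series" means these compounds.

Compound 1 `COc1ccc(CCCc2ccc(OC)cc2OC)c(O)c1`: 100%
Compound 2 `COc1ccc(C(=O)/C=C/c2ccc(OC)c(OC)c2)c(O)c1`: 99.7%

Both compounds were tested in an ADME assay on RAW264.7 cells (Mus musculus) for cytotoxicity, read by MTT assay, with a stated time of 24 h, tested at 1.25 ug/mL; on this read-out higher numbers stand for a weaker effect at the one concentration tested and lower numbers for a stronger effect. In this assay compound 1 gives 100%, and compound 2 gives 99.7%. Compound 2 holds the lowest of the two numbers, but its nearest neighbour, compound 1, lies within the scatter, so no order between the two can be read.

Compound 3 `COc1ccc(C(=O)/C=C/c2ccc(OC)c(OC)c2OC)c(O)c1` has not yet been measured. It differs from compound 2 in one place: methoxy in place of hydrogen on an aromatic carbon. For the measured compounds named here, no step between two measured compounds is known here, so nothing shows how such a change moves this read-out. Both measured values sit at the weak end of the scale with only a trace of effect. The step of a number 0.7 percentage points lower from compound 2 to compound 3 (within the scatter) is expected to stay within the scatter, with no direction beyond it. Compound 3 is therefore estimated at 99%, in a range from 90% to 100%.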

Compound 3, a percentage reported as activity, at one concentration (the size of the read-out at that concentration, not a potency): 98.5%
Estimate against measurement, compound 3: 0.5 percentage points above; the range from low to high includes it.
By their numbers in this assay, from the lowest: compounds 3, 2 and 1 (each within the scatter of the next).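

For the compounds shown here, the step at this position is the first single change available in this assay: methoxy in place of hydrogen on an aromatic carbon, ortho to a large group, ortho to a methoxy group and meta to a methoxy group, comes with a number 1.2 percentage points lower from compound 2 to compound 3 (within the scatter). At the one concentration tested, this position therefore accepts a methoxy group without a shift beyond the scatter, and compound 3 remains at the weak end of the scale. Nothing among the available data explains this result.

On these data alone, whether an amine or a carboxylic acid on the same aromatic carbon would give a step beyond the scatter remains open. Also open, as far as these compounds go, is how compound 2 and compound 3 compare at higher concentrations, where an effect might become large enough to separate them.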